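The compounds below may be only part of what the source reports. "The series", "measured", "known", "first", "only" and "open" are said of these compounds alone.

In a functional assay on WM1361 cells (Homo sapiens) for antiproliferative activity, read by MTT assay, with a stated time of 48 h (on this read-out higher numbers stand for weaker inhibition and lower numbers for stronger inhibition), compound 1 `O=C(Nc1cc(-c2ccccc2)[nH]n1)c1cccnc1F` gives 14600 nM, compound 2 `Cc1ccc(-c2cc(NC(=O)c3ccc(Br)nc3)n[nH]2)cc1` gives 18600 nM and compound 3 `O=C(Nc1cc(-c2ccc(Br)cc2)[nH]n1)c1cccnc1F` gives 15700 nM. These three values lie within the scatter of one another, so compound 3 holds no distinct place among them. Compound 4 `O=C(Nc1cc(-c2ccc(Br)cc2)[nH]n1)c1ccc(Br)nc1` differs from compound 3 by 6-bromopyridin-3-yl in place of 2-fluoropyridin-3-yl on a carbonyl carbon. Going by the values given here, the one measured single change, bromo in place of hydrogen on an aromatic carbon, gives a 1.1-fold higher number from compound 1 to compound 3 (0.03 log units; within the scatter). Compound 2, which already carries 6-bromopyridin-3-yl, stands at 18600 nM. No step beyond the scatter is therefore expected in this assay. The expected step is a 1.1-fold higher number from compound 3 to compound 4 (0.03 log units; within the scatter). Compound 4 is estimated at 17000 nM, with an expected range of 9000 nM to 32000 nM.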

Compound 4, half-maximal inhibitory concentration: 20600 nM
Compound 4: the middle estimate sits 1.2-fold (0.08 log units) below what was measured; low and high end bracket the measured number.
By their numbers in this assay, from the lowest: compounds 1, 3, 2 and 4 (each within the scatter of the next).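

In this assay the exchange of 2-fluoropyridin-3-yl for 6-bromopyridin-3-yl on the carbonyl carbon gives a 1.3-fold higher number from compound 3 to compound 4 (0.12 log units; within the scatter) and so brings no step beyond the scatter at this position. With 6-bromopyridin-3-yl in place, bromo in place of methyl on an aromatic carbon gives a 1.1-fold higher number from compound 2 to compound 4 (0.04 log units; within the scatter) and likewise leaves the number unmoved beyond the scatter. Nothing available bears on why these steps stay this small.

From the compounds shown here alone, whether an amine or a carboxylic acid in place of 6-bromopyridin-3-yl on the carbonyl carbon would give a step beyond the scatter remains open.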